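A Chloro Swap on a Core Giving Only Limits

This account rests on a few compounds, and the source may have more. Where it says the series, first, only, none or still open, it means among the compounds named here.

Compound 1 `Cc1ccc(-c2nc3ccccn3c2Sc2ccccc2)cc1` gives > 100000 nM in an ADME assay on HEK293 cells (Homo sapiens) for inhibition, read by MTT assay, with a stated time of 48 h; on this read-out higher numbers stand for weaker inhibition and lower numbers for stronger inhibition; this value is a limit of the assay, not a number.
Compound 2 `c1ccc(Sc2c(-c3ccccc3)nc3ccc(-c4ccccc4)cn23)cc1` gives > 100000 nM in this assay; this too is a limit.
Compound 3 `Cc1ccc(-c2nc3ccc(C)cn3c2Sc2ccccc2)cc1` gives > 100000 nM in this assay, again a limit.

Compound 2 therefore stands at the limit of this assay, and only a limit is known for it. The same holds across the small set, since the limit of > 100000 nM in this assay, at which 3 of the 3 values shown sit, describes every value shown. Among the measured compounds shown here, the one measured step that changes a single place, a step that the two limits leave unreadable from compound 1 to compound 3, methyl in place of hydrogen on an aromatic carbon, runs between two limits and so has no readable size.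

Compound 4 `Clc1ccc2nc(-c3ccccc3)c(Sc3ccccc3)n2c1` differs from compound 2 by chloro in place of phenyl on an aromatic carbon. No measured step bears on this change with a readable size, so no direction and no size can be drawn from the data; the only pattern shown is that every compound sits at the limit.

Compound 4 is therefore expected to sit near the same limit in this assay, with an estimated value of 150000 nM between 50000 nM and 500000 nM. The step that the limit leaves unreadable from compound 2 to compound 4 is expected to be none beyond the scatter.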

Compound 4, half-maximal inhibitory concentration: > 100000 nM
Compound 4: only a limit was reported; the forecaster's own chance of this, stated with the estimate: 80%; the middle value is on the limit's open side.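

The step from compound 2 to compound 4, chloro in place of phenyl on an aromatic carbon, runs between two limits, so no new step can be read. Every compound shown gives the same result: the limit of > 100000 nM in this assay, at which 4 of the 4 values shown sit.

What stays open is how strongly any of these compounds acts in this assay and whether any change to the shared core alters that.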